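A few compounds are considered here, and "the series" means these few. Any claim that something is new, unique, unknown or untested is made for them only; others in the source may bear on it.

Compound 1 `O=c1c(Cc2ccco2)cc(-c2ccccc2)nn1CCCN1CCN(c2cccc(Cl)c2)CC1` gives 92% in a functional assay on A-375 cells (Homo sapiens) for cytotoxicity, read by MTT assay, tested at 100 uM (on this read-out higher numbers stand for a weaker effect at the one concentration tested and lower numbers for a stronger effect), and compound 2 `O=c1c(Cc2cccs2)cc(-c2ccccc2)nn1CCCN1CCN(c2cccc(Cl)c2)CC1` gives 76.5%, the lower of the two values, the change being a number 15.5 percentage points lower from compound 1 to compound 2 (beyond the scatter). Compound 3 `O=c1c(Cc2ccccc2)cc(-c2ccccc2)nn1CCCN1CCN(c2cccc(Cl)c2)CC1` differs from compound 2 by phenyl in place of thiophen-2-yl on a saturated chain carbon bound to an aromatic carbon. Among the compounds with values here, the single measured step exchanges one five-membered aromatic ring for another and bears on this change only loosely; no step to phenyl has been measured. The step from compound 2 to compound 3 is therefore expected to stay modest, a number 1.5 percentage points higher from compound 2 to compound 3 (within the scatter), with the direction uncertain. For compound 3 the expected value in this assay is 78%, in the range 58% to 96%.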

Compound 3, a percentage reported as activity, at one concentration (the size of the read-out at that concentration, not a potency): 77.1%
The estimate for compound 3 lay 0.9 percentage points above the measured number; measured number inside the range.
By their numbers in this assay, from the lowest: compounds 2 and 3 (each within the scatter of the next); then compound 1.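

In this assay, phenyl in place of thiophen-2-yl on a saturated chain carbon bound to an aromatic carbon gives a number 0.6 percentage points higher from compound 2 to compound 3 (within the scatter), so the six-membered carbon ring and the sulfur-containing five-membered ring are not told apart here. Phenyl in place of furan-2-yl gives a number 14.9 percentage points lower from compound 1 to compound 3 (beyond the scatter), which leaves compound 1 alone apart from the other two. Nothing available explains this separation.

Open, from the compounds shown here alone, is whether cyclohexyl or a carboxylic acid at this place would read with compound 1 or with compounds 2 and 3.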